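The source may report more compounds than this note shows. Statements on the series, on what has been measured and on what is new or still open speak of the compounds shown alone.

Compound 1 `Cn1cnc2c(N3CCCCC3)nc(-c3cccc(O)c3)nc21`: 49.1%
Compound 2 `Cn1cnc2c(N3CCCCC3)nc(-c3cccc(Cl)c3)nc21`: 6.1%

In an assay on cells for displacement of a labelled ligand from adenosine receptor A3 (Homo sapiens), read by scintillation counting and radioligand binding, with a stated time of 180 min, tested at 10 uM (on this read-out lower numbers stand for less inhibition and higher numbers for more inhibition at the one concentration tested (going by the name of the read-out)), compound 2 gives 6.1%, the lowest of the two numbers; compound 1 gives 49.1%. Compound 3 `Cn1cnc2c(N3CCCCC3)nc(-c3ccccc3Cl)nc21` differs from compound 2 by 2-chlorophenyl in place of 3-chlorophenyl on an aromatic carbon. Within the data shown here, the one measured step, a number 43 percentage points lower from compound 1 to compound 2 (beyond the scatter), exchanges hydroxy for chloro and says nothing about where the chlorine sits on the phenyl ring, so no measured step bears directly on this change. Starting from the lowest number, compound 3 is expected to stay close to compound 2, with a number 5.9 percentage points higher from compound 2 to compound 3 (within the scatter) expected to lie within the scatter. Compound 3 is therefore estimated at 12%, between 0% and 40%.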

Compound 3, a percentage reported as inhibition, at one concentration (the size of the read-out at that concentration, not a potency): 2.1%
Compound 3: middle estimate off by 9.9 percentage points, on the high side; the range from low to high includes it.
By their numbers in this assay, from the lowest: compounds 3 and 2 (each within the scatter of the next); then compound 1.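

Moving the chlorine from 3-chlorophenyl to 2-chlorophenyl makes no readable difference in this assay, with a number 4 percentage points lower from compound 2 to compound 3 (within the scatter). The drop from the hydroxy compound therefore appears with either chlorine placement, since 2-chlorophenyl in place of 3-hydroxyphenyl gives a number 47 percentage points lower from compound 1 to compound 3 (beyond the scatter). No supporting data offer an explanation for these numbers.

Still open, as far as these compounds go, is whether 2-hydroxyphenyl would read like 3-hydroxyphenyl, which would show whether the position matters for the hydroxy group. Also open, from the compounds shown here alone, is how an amine or a carboxylic acid at either position on the phenyl ring would compare.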